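Moving the methoxy group on a thiadiazole-thiazole anticonvulsant scaffold

A few compounds are considered here, and "the series" means these few. Any claim that something is new, unique, unknown or untested is made for them only; others in the source may bear on it.

Four compounds share a core in which a thiadiazole bearing two amino linkers joins an aryl group to a thiazole. Compound 1 `COc1ccccc1Nc1nnc(Nc2nc(-c3ccc([N+](=O)[O-])cc3)cs2)s1` carries a 2-methoxyphenyl on one nitrogen and a nitro-bearing phenyl on the thiazole. In a functional assay on the whole organism (strain albino) with Mus musculus as the target, in the maximal electroshock model, with a stated time of 4 h (a lower number here means that less compound is needed, a higher number that more compound is needed for the effect), compound 1 gives 300 mg/kg. Compound 2 `COc1ccc(Nc2nnc(Nc3nc(-c4ccc([N+](=O)[O-])cc4)cs3)s2)cc1` differs only in the change (4-methoxyphenyl in place of 2-methoxyphenyl on a nitrogen on an aromatic ring), and in this assay compound 2 gives 30 mg/kg, so the step of a 10-fold lower number from compound 1 to compound 2 (1.00 log units; beyond the scatter) is a clear gain. Compound 3 `COc1ccccc1Nc1nnc(Nc2nc(-c3ccccc3)cs2)s1` keeps the 2-methoxyphenyl of compound 1 but differs by hydrogen in place of nitro on an aromatic carbon; in this assay compound 3 gives 300 mg/kg, and the step of no change at the digits printed from compound 1 to compound 3 (within the scatter) shows that removing the nitro group left the dose unchanged.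

Compound 4 `COc1ccc(Nc2nnc(Nc3nc(-c4ccccc4)cs3)s2)cc1` has not yet been tested. Relative to compound 3 it shows the change (4-methoxyphenyl in place of 2-methoxyphenyl on a nitrogen on an aromatic ring). This is the same change as between compound 1 and compound 2, made on a core that differs by the hydrogen in place of nitro just described. Since the nitro group made no difference between compound 1 and compound 3, the methoxy shift is expected to act on compound 3 as it did on compound 1, and the step of a 5.0-fold lower number from compound 3 to compound 4 (0.70 log units; beyond the scatter) is therefore expected to be of similar size to a 10-fold lower number from compound 1 to compound 2 (1.00 log units; beyond the scatter). On that basis compound 4 is estimated to give 60 mg/kg in this assay, with a likely range from 30 mg/kg to 300 mg/kg.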

Compound 4, minimum effective dose: 100 mg/kg
The estimate for compound 4 lay 1.7-fold (0.22 log units) below the measured number, and the stated range covers the measured number.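

In this assay the shift to 4-methoxyphenyl again lowers the number, a 3.0-fold lower number from compound 3 to compound 4 (0.48 log units; beyond the scatter), so the direction of the change carries over to the core without the nitro group, but its size does not: the same change on two cores in this assay, a 10-fold lower number (1.00 log units; beyond the scatter) from compound 1 to compound 2 and a 3.0-fold lower number (0.48 log units; beyond the scatter) from compound 3 to compound 4, 3.3-fold (0.52 log units) apart, beyond the scatter of two such steps

The same holds when the pair is read the other way: removing the nitro group leaves the number unchanged with the 2-methoxyphenyl present but gives a 3.3-fold higher number from compound 2 to compound 4 (0.52 log units; beyond the scatter) with the 4-methoxyphenyl present, so the two changes do not act independently of each other here: the same change on two cores in this assay, no change at the digits printed (within the scatter) from compound 1 to compound 3 and a 3.3-fold higher number (0.52 log units; beyond the scatter) from compound 2 to compound 4, 3.3-fold (0.52 log units) apart, beyond the scatter of two such steps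

Among these compounds, this shows that the step for the methoxy shift depends on the group at the other end of the molecule, but with only two cores it does not show how general that dependence is, nor does it give any reason for it.

The compounds shown leave open whether the shift keeps its direction on cores with another group in place of the nitro, such as an amine or a carboxylic acid. They also leave open whether a longer chain, such as an ethoxy group in place of the methoxy, would follow the same course in this whole-animal test.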